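The compounds below may be only part of what the source reports. "The series", "measured", "known", "first", "only" and "open" are said of these compounds alone.

Compound 1, with structure `Cc1nn(-c2ncnc3nc[nH]c23)c2c1C(OC1CCCC1)CC(=O)N2`, serves as the reference point. In a functional assay on HEK293 cells for agonist activity at G-protein coupled receptor 39 (Homo sapiens), read by scintillation proximity assay and inositol phosphate accumulation, with a stated time of 75 min, in the presence of a further agent that is not named here (on this read-out higher numbers stand for an effect only at larger amounts of compound and lower numbers for an effect already at smaller amounts), compound 1 gives 2 nM. Two related compounds have been measured alongside it. Compound 2 `Cc1nn(-c2ncnc3nc[nH]c23)c2c1C(OCc1ccc(C#N)cc1)CC(=O)N2` gives 4 nM in this assay, and compound 3 `Cc1nn(-c2ncnc3nc[nH]c23)c2c1C(OCCc1ccccc1)CC(=O)N2` gives 3 nM. Compound 1 shows the lowest of the three numbers, yet its separations from the other two are small: the step of a 1.5-fold higher number from compound 1 to compound 3 (0.18 log units; within the scatter) and the step of a 2.0-fold higher number from compound 1 to compound 2 (0.30 log units; within the scatter) both lie within the scatter, as does the step of a 1.3-fold lower number from compound 2 to compound 3 (0.12 log units; within the scatter).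

Compound 4 `Cc1nn(-c2ncnc3nc[nH]c23)c2c1C(OCc1ccccc1Cl)CC(=O)N2` has not yet been measured. Relative to compound 1 the change is 2-chlorobenzyl in place of cyclopentyl on an oxygen on a saturated carbon. Within the data shown here, the steps that bear on this change are those in which the cyclopentyl on an oxygen on a saturated carbon was replaced by an aromatic-ring-bearing group: the step of a 2.0-fold higher number from compound 1 to compound 2 (0.30 log units; within the scatter) and the step of a 1.5-fold higher number from compound 1 to compound 3 (0.18 log units; within the scatter). Neither moved the number beyond the scatter, so exchanging cyclopentyl for 2-chlorobenzyl at this position is expected to leave the read-out in this assay essentially unchanged, with the expected step of a 1.5-fold higher number from compound 1 to compound 4 (0.18 log units; within the scatter). For compound 4 the estimate in this assay is 3 nM, with a likely range from 1.2 nM to 8 nM.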

Compound 4, half-maximal effective concentration: 2 nM
Compound 4: the middle estimate sits 1.5-fold (0.18 log units) above what was measured, and the stated range covers the measured number.
By their numbers in this assay, from the lowest: compounds 1, 4, 3 and 2 (each within the scatter of the next).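

In this assay, the step to the 2-chlorobenzyl ether gives no change at the digits printed from compound 1 to compound 4 (within the scatter), so a six-membered aromatic ring carrying chlorine, with 8 heavy atoms in the entering group against 5 in cyclopentyl, leaves the read-out where the cyclopentyl ring had it. The comparisons among the ring-bearing groups also stay flat: a 1.5-fold lower number from compound 3 to compound 4 (0.18 log units; within the scatter) and a 2.0-fold lower number from compound 2 to compound 4 (0.30 log units; within the scatter) show that 2-chlorophenyl on the saturated chain carbon is not told apart from either benzyl or 4-cyanophenyl, which extends the tolerance seen so far to a chlorine-bearing benzyl group, and all four groups on this oxygen now lie within the scatter of one another. Nothing available explains why these exchanges change so little.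

All four groups on this oxygen are large and ring-bearing, so the compounds shown leave open whether a small methyl, a longer chain ending in a primary amine, or a benzyl group carrying a carboxylic acid would hold the read-out at this level. They also leave open whether the flat picture extends to the free hydroxyl in place of the ether, or to changes elsewhere on the shared core.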